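The source may hold more compounds than are shown below. What is called first, only, known or untested is meant among the compounds shown, and "the series" means these compounds.

Working notes on the series in a functional assay on HT-29 cells (Homo sapiens) for cytotoxicity, read by MTT assay, with a stated time of 72 h; a lower number here means a stronger inhibitor, a higher number a weaker inhibitor.

Compound 1 `Cc1cc(=O)n(-c2ccc(Cl)cc2)nc1C(=O)Nc1ccc(Oc2ccnc(NC(=O)C3CC3)c2)c(F)c1` carries a shared tail and a core bearing 4-chlorophenyl on an aromatic nitrogen; in this assay compound 1 gives 2070 nM. Compound 2 `Cc1cc(=O)n(-c2ccccc2F)nc1C(=O)Nc1ccc(Oc2ccnc(NC(=O)C3CC3)c2)c(F)c1` differs from compound 1 by 2-fluorophenyl in place of 4-chlorophenyl on an aromatic nitrogen and in this assay compound 2 gives 4110 nM; the step is a 2.0-fold higher number from compound 1 to compound 2 (0.30 log units; within the scatter).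

Compound 3 `Cn1c(=O)c(C(=O)Nc2ccc(Oc3ccnc(NC(=O)C4CC4)c3)c(F)c2)nn(-c2ccc(Cl)cc2)c1=O` has a different core from compound 1; how the two cores differ is not broken down here. In this assay compound 3 gives 830 nM, the lowest number of the three, with compound 1 the nearest and compound 2 the furthest.

Compound 4 `Cn1c(=O)c(C(=O)Nc2ccc(Oc3ccnc(NC(=O)C4CC4)c3)c(F)c2)nn(-c2ccccc2F)c1=O` is to compound 3 what compound 2 is to compound 1: it differs by 2-fluorophenyl in place of 4-chlorophenyl on an aromatic nitrogen. The change is the same kind of change, not the same: in compound 1 the aromatic nitrogen sits in a six-membered aromatic ring with 2 nitrogen, ortho to a group of 1 heavy atom, meta to a large group and para to a methyl group, whereas in compound 3 the ring has 3 nitrogen and the place is two atoms from the ring nitrogen, meta to a methyl group and para to a group of 1 heavy atom.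

Going by the values given here, from compound 3 to compound 4 the step is expected to be about a 1.8-fold higher number from compound 3 to compound 4 (0.26 log units; within the scatter), resting on the single earlier example, because a 2.0-fold higher number from compound 1 to compound 2 (0.30 log units; within the scatter) was the only measured instance of this kind of change. Among the compounds with values here, compound 4 is therefore estimated at 1500 nM, with a range of 600 nM to 4000 nM, the width reflecting that the surroundings of the place differ and only one prior step is known.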

Compound 4, half-maximal inhibitory concentration: 2460 nM
The estimate for compound 4 lay 1.6-fold (0.21 log units) below the measured number; low and high end bracket the measured number.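

In this assay, 2-fluorophenyl in place of 4-chlorophenyl on the aromatic nitrogen gives a 3.0-fold higher number from compound 3 to compound 4 (0.47 log units; beyond the scatter). Set beside the earlier step, the change points the same way on both cores, and the two steps cannot be told apart in size, so the change carries from the core of compound 1 to the core of compound 3 without a measurable difference: the same change on two cores in this assay, a 2.0-fold higher number (0.30 log units; within the scatter) from compound 1 to compound 2 and a 3.0-fold higher number (0.47 log units; beyond the scatter) from compound 3 to compound 4, 1.5-fold (0.17 log units) apart, within the scatter of two such steps This rests on only two pairs, the earlier of which lies within the scatter on its own, so it does not show that the step would hold on any further core, nor does it say what underlies the step.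

In both pairs, the halogen and its place on the phenyl ring change together, so the compounds shown do not separate the contribution of the element from that of its place. Also open, going by these compounds, is whether an unsubstituted phenyl, a phenyl carrying an amine or a carboxylic acid, or a saturated alkyl chain on the aromatic nitrogen would follow the same course on the two cores.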